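A few compounds are considered here, and "the series" means these few. Any claim that something is new, unique, unknown or untested is made for them only; others in the source may bear on it.

Measured so far in a functional assay on B16-F10 cells (Mus musculus) for cytotoxicity, read by MTT assay, with a stated time of 48 h; on this read-out lower numbers stand for stronger inhibition and higher numbers for weaker inhibition:
Compound 1 `COc1ccc(N/C=C\C(=O)c2nc(-c3ccc(C(F)(F)F)cc3)n3ccccc23)cc1OC` gives > 30000 nM, a limit of the assay.
Compound 2 `COc1ccc(N/C=C\C(=O)c2nc(-c3ccc(F)cc3)n3ccccc23)cc1` gives 2560 nM.
Compound 3 `O=C(/C=C\Nc1ccc(F)cc1)c1nc(-c2ccc(C(F)(F)F)cc2)n2ccccc12` gives > 30000 nM, again a limit of the assay.

Going by the values given here, compound 3 therefore stands at the assay limit, as does compound 1; compound 2 is the only member with a numerical value, and the limit of > 30000 nM in this assay, at which 2 of the 3 values shown sit, is the state of the set. Among the compounds with values here, the one step within the measured compounds, a step that the two limits leave unreadable from compound 1 to compound 3, runs from limit to limit and cannot be sized.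

Compound 4 `COc1ccc(N/C=C\C(=O)c2nc(-c3ccc(C(F)(F)F)cc3)n3ccccc23)cc1` differs from compound 3 by methoxy in place of fluoro on an aromatic carbon. Within the data shown here, no measured step bears directly on this change. Compound 2, which carries the (4-methoxyphenyl)amino group beside a fluorophenyl on the core, gives a number rather than a limit, while both compounds bearing the trifluoromethylphenyl on the core sit at the limit. On this basis compound 4 is expected to stay near the limit, with the step of an at least 1.2-fold lower number from compound 3 to compound 4 (0.07 log units; that floor lies within the scatter) expected to be unreadable or small; the estimate for compound 4 is 25000 nM, within 5000 nM to 100000 nM.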

Compound 4, half-maximal inhibitory concentration: > 30000 nM
Compound 4 gave a limit, no number; the forecaster's own chance of this, stated with the estimate: 55%; at least 1.2-fold (0.07 log units) between middle value and limit.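

In this assay compound 4 gives > 30000 nM, a limit of the assay. Going by these compounds alone, with the (4-methoxyphenyl)amino group held constant, changing fluoro to trifluoromethyl gives an at least 11-fold higher number from compound 2 to compound 4 (1.06 log units; beyond the scatter), the first step that can be sized. The steps that link compound 4 to compound 1 and compound 3 cannot be read, so the substituents on the amino-bearing phenyl stay unranked while the trifluoromethyl group is present, and most of the series remains at one ceiling: the limit of > 30000 nM in this assay, at which 3 of the 4 values shown sit.

Open, on these data alone, is whether methoxy, fluoro or the dimethoxy pattern on that phenyl would separate once the other aromatic ring carries fluoro. Also open, as far as these compounds go, is whether chloro or methyl in place of trifluoromethyl would give a number rather than a limit.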